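The compounds below may be only part of what the source reports. "The series", "measured", "known", "first", "only" and "open" are said of these compounds alone.

Measured compounds in the series:
- compound 1, `C/C(=C1/OC(=O)NC1=O)C(c1ccc(-c2ccc3cccc(F)c3c2)[nH]c1=O)C(C)C`: 12700 nM
- compound 2, `CC(C)C(/C=C1\OC(=O)NC1=O)c1cc(Cl)c(-c2ccc3cccc(F)c3c2)[nH]c1=O`: 3200 nM
- compound 3, `CC(C)[C@@H](c1ccc(-c2ccc3cccc(F)c3c2)[nH]c1=O)[C@H]1OC(=O)NC1=O`: 5400 nM

In a physicochemical assay for solubility, measured as kinetic solubility, at pH 2 (on this read-out higher numbers stand for higher solubility and lower numbers for lower solubility), compound 1 gives 12700 nM, the highest of the three numbers. Compound 3 stands nearest at 5400 nM, a gap beyond the scatter; compound 2 stands furthest at 3200 nM, also beyond the scatter. Within the data shown here, no step between compounds differing in one place has been measured, so the series offers no direct calibration for any single change.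

Compound 4, `CC(C)C(c1ccc(-c2ccc3cccc(F)c3c2)[nH]c1=O)C1SC(=O)NC1=O`, is not yet measured in this assay. Against compound 1 the change is a group of 7 heavy atoms (3 carbon, 1 nitrogen, 2 oxygen, 1 sulfur; one five-membered non-aromatic ring with 2 hetero atoms) in place of a group of 9 heavy atoms (5 carbon, 1 nitrogen, 3 oxygen; one five-membered non-aromatic ring with 2 hetero atoms), on a saturated chain carbon bound to an aromatic carbon and a saturated chain carbon. The group that enters is the 2,4-dioxo-1,3-thiazolidin-5-yl, on a saturated chain carbon bound to an aromatic carbon and a saturated chain carbon; the group that leaves carries one more double bond outside aromatic rings.

Compound 3, which also carries its five-membered ring on a saturated carbon, gives 5400 nM, a lower number than compound 1. On that basis a modest downward step from compound 1 to compound 4 is expected, a 2.0-fold lower number from compound 1 to compound 4 (0.29 log units; within the scatter), though it may fall within the scatter. Compound 4 is estimated at 6500 nM, with a range from 2200 nM to 19000 nM.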

Compound 4, solubility: 11300 nM
Compound 4: middle estimate off by 1.7-fold (0.24 log units), on the low side, and the stated range covers the measured number.
By their numbers in this assay, from the lowest: compounds 2 and 3 (each within the scatter of the next); then compounds 4 and 1 (each within the scatter of the next).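

In this assay, placing the 2,4-dioxo-1,3-thiazolidin-5-yl on the saturated chain carbon bound to an aromatic carbon and a saturated chain carbon gives a 1.1-fold lower number from compound 1 to compound 4 (0.05 log units; within the scatter), so this exchange leaves no readable change at this position. Among these compounds, this is the first step in which two measured compounds differ in one place, and it shows that the position takes a group of 7 heavy atoms with 2 double bonds outside aromatic rings in place of a group of 9 heavy atoms with 3, with the numbers staying level. No measurement is at hand that could explain this outcome.

As far as these compounds go, whether a five-membered ring is needed at this position at all remains open, as a carboxylic acid or an amine on the same carbon would show. From the compounds shown here alone, how a longer chain in that place would read also remains open.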